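Compound 4: Trifluorophenyl in Place of Bromophenyl

This account rests on a few compounds, and the source may have more. Where it says the series, first, only, none or still open, it means among the compounds named here.

Compound 1 `COc1ccccc1-n1cc(C(=O)c2cc(OC)c(OC)c(OC)c2)c(-c2ccccc2)c1` gives 150 nM in a functional assay on MCF7 cells (Homo sapiens) for cytotoxicity, read by MTT assay, with a stated time of 96 h; on this read-out higher numbers stand for weaker inhibition and lower numbers for stronger inhibition.
Compound 2 `COc1ccc(-n2cc(C(=O)c3cc(OC)c(OC)c(OC)c3)c(-c3ccccc3)c2)cc1` gives 120 nM.
Compound 3 `COc1cc(C(=O)c2cn(-c3ccccc3)cc2-c2ccc(Br)cc2)cc(OC)c1OC` gives 340 nM.

Compound 3 stands highest of the three numbers; compound 1 and compound 2 both give lower numbers, and each of those gaps lies beyond the scatter. Among the measured compounds shown here, the one measured step, a 1.3-fold lower number from compound 1 to compound 2 (0.10 log units; within the scatter), concerns the group on the aromatic nitrogen and lies within the scatter; it does not touch the carbon that carries the aryl group.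

Compound 4 `COc1cc(C(=O)c2cn(-c3ccccc3)cc2-c2c(F)cc(F)cc2F)cc(OC)c1OC` differs from compound 3 by 2,4,6-trifluorophenyl in place of 4-bromophenyl on an aromatic carbon. For the measured compounds named here, no measured step covers this position, so there is nothing in the data to point to a direction. The expectation is therefore an estimated step of a 1.1-fold lower number from compound 3 to compound 4 (0.05 log units; within the scatter), with the middle kept close to compound 3 and a wide range. Compound 4 is expected to give 300 nM, between 120 nM and 750 nM.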

Compound 4, half-maximal inhibitory concentration: 180 nM
Estimate against measurement, compound 4: 1.7-fold (0.22 log units) above; low and high end bracket the measured number.
By their numbers in this assay, from the lowest: compounds 2, 1, 4 and 3 (each within the scatter of the next, the first and the last beyond it).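

The change from 4-bromophenyl to 2,4,6-trifluorophenyl gives the first step read at this aromatic carbon, and in this assay it stays within the scatter, with a 1.9-fold lower number from compound 3 to compound 4 (0.28 log units; within the scatter) as its size. Among the compounds shown here, the earlier step concerned only the group on the aromatic nitrogen, so this is the first sign that this position accepts one halogenated phenyl in place of another without a change beyond the scatter. No evidence is at hand that bears on this result.

Open, from the compounds shown here alone, is how this aromatic carbon responds to a different kind of group, such as an aminophenyl, a carboxyphenyl or a pyridine ring. Also open, going by these compounds, is whether a methoxyphenyl on the aromatic nitrogen, as in compound 1 and compound 2, would read the same alongside 2,4,6-trifluorophenyl.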